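From 3-methoxybenzyl to 2-methoxybenzyl in the series

A few compounds are considered here, and "the series" means these few. Any claim that something is new, unique, unknown or untested is made for them only; others in the source may bear on it.

For the measured compounds named here, in a functional assay on L6 cells (Rattus norvegicus) for inhibition, read by scintillation counting, with a stated time of 3 h (on this read-out lower numbers stand for stronger inhibition and higher numbers for weaker inhibition), compound 1 `O=C(O)C[C@H](O)C[C@H](O)CCn1c(-c2ccc(F)cc2)nc(C(=O)NCc2ccc(F)cc2)c1C1CC1` gives 1620 nM and compound 2 `COc1cccc(CNC(=O)c2nc(-c3ccc(F)cc3)n(CC[C@@H](O)C[C@@H](O)CC(=O)O)c2C2CC2)c1` gives 538 nM, so compound 2 holds the lower of the two numbers so far. Compound 3 `COc1ccccc1CNC(=O)c1nc(-c2ccc(F)cc2)n(CC[C@@H](O)C[C@@H](O)CC(=O)O)c1C1CC1` keeps the rest of compound 2 and places 2-methoxyphenyl in place of 3-methoxyphenyl on a saturated chain carbon bound to an amide-type nitrogen.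

Going by the values given here, only one measured step bears on this change: a 3.0-fold lower number from compound 1 to compound 2 (0.48 log units; beyond the scatter). That modest step, beyond the scatter, exchanged 4-fluorophenyl for 3-methoxyphenyl at the same place. It therefore gives a rough scale for changes there but does not test two methoxyphenyl groups against each other. Among the compounds with values here, no measured pair does, so the direction remains open and a step larger than the one seen is not expected. The expected step is a 1.2-fold higher number from compound 2 to compound 3 (0.08 log units; within the scatter), which would lie within the scatter, so no clear change is expected in this assay. For compound 3 the estimated value is 650 nM, with an expected range from 230 nM to 1800 nM.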

Compound 3, half-maximal inhibitory concentration: 10700 nM
For compound 3 the middle estimate is 16-fold (1.22 log units) below the measured one; the whole stated range lies below it.
By their numbers in this assay, from the lowest: compound 2; then compound 1; then compound 3.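

In this assay, exchanging 3-methoxybenzyl for 2-methoxybenzyl leaves the heavy atoms and the counted hydrogen-bond donors and acceptors unchanged, yet it gives a 20-fold higher number from compound 2 to compound 3 (1.30 log units; beyond the scatter), so this place in the series distinguishes between two isomeric groups far more sharply than the modest earlier step suggested. The 2-methoxybenzyl amide also compares poorly with the 4-fluorobenzyl amide, with a 6.6-fold higher number from compound 1 to compound 3 (0.82 log units; beyond the scatter), so the three groups at this place run from 3-methoxyphenyl through 4-fluorophenyl to 2-methoxyphenyl in order of rising number, and a methoxy group does not by itself give the lower number. Nothing available explains why the 2-methoxybenzyl group gives so much weaker inhibition here.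

Still open, going by these compounds, is where a plain benzyl or a 4-methoxybenzyl group would fall against these three. It is also unclear whether a 2-fluorobenzyl or 2-methylbenzyl group would share the high number of compound 3, which would tie the drop to any group at that ring position rather than to the methoxy group itself.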